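A Second Chloro on the Core of Compound 2

The source may hold more compounds than are shown below. What is called first, only, known or untested is meant among the compounds shown, and "the series" means these compounds.

Compound 1, `ClCc1cccc(Cn2cnc3c(Cl)ncnc32)c1`: 4070 nM
Compound 2, `ClCc1ccccc1Cn1cnc2ncnc(Cl)c21`: 17400 nM
Compound 3, `ClCc1cccc(Cn2cnc3nc(Cl)nc(Cl)c32)c1`: 30900 nM

Of the compounds shown here, three have been tested so far in a functional assay on NCI-H23 cells (Homo sapiens) for cytotoxicity, read by sulforhodamine B assay, with a stated time of 48 h; a higher number here means a weaker inhibitor of growth, a lower number a stronger inhibitor of growth. Compound 2 stands at the second highest number of the three. Its nearest neighbour is compound 3, whose value lies within the usual scatter of it, so no order can be read between those two. Its furthest is compound 1, which gives a lower number by a margin beyond the scatter.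

Compound 4, `ClCc1ccccc1Cn1cnc2nc(Cl)nc(Cl)c21`, has not yet been measured. It differs from compound 2 in one spot: chloro in place of hydrogen on an aromatic carbon. Among the compounds with values here, no measured pair shows exactly this change, so the size of the step can only be guessed. Because compound 3 gives 30900 nM, the highest number of the set, an increase is expected for compound 4 rather than a decrease, and the step from compound 2 to compound 4 is estimated at a 2.9-fold higher number from compound 2 to compound 4 (0.46 log units; beyond the scatter). Compound 4 is thus expected to give about 50000 nM, with a range from 15000 nM to 150000 nM.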

Compound 4, concentration for total growth inhibition: 40700 nM
For compound 4 the middle estimate is 1.2-fold (0.09 log units) above the measured one, within the range that was stated.
By their numbers in this assay, from the lowest: compound 1; then compounds 2, 3 and 4 (each within the scatter of the next, the first and the last beyond it).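

In this assay, chloro in place of hydrogen on the aromatic carbon between two ring nitrogen atoms gives the first step seen for this change, a 2.3-fold higher number from compound 2 to compound 4 (0.37 log units; beyond the scatter). The number moves toward weaker inhibition of growth, so adding this one chlorine atom does not strengthen the effect here, although the step is modest. No measurement at hand bears on why the number rises.

This single step cannot tell whether the rise belongs to chloro alone or would follow any group placed on this carbon. An amine, a methoxy group or a nitrile on the same carbon would help to separate those two readings, and each could move the number either way.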